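Trimethoxyphenyl in place of 4-fluorophenyl: expectation for compound 4

The source may hold more compounds than are shown below. What is called first, only, known or untested is meant among the compounds shown, and "the series" means these compounds.

In a functional assay on A549 cells (Homo sapiens) for cytotoxicity, read by MTT assay, with a stated time of 72 h (on this read-out lower numbers stand for stronger inhibition and higher numbers for weaker inhibition), compound 1 (`O=C(N/N=C/c1ccc(F)cc1)Nc1cc2c(Nc3ccc(F)c(Cl)c3)ncnc2cc1O[C@H]1CCOC1`) gives 35100 nM, compound 2 (`COc1cc(/C=N/NC(=O)Nc2cc3c(Nc4ccc(F)c(Cl)c4)ncnc3cc2O[C@H]2CCOC2)cc(OC)c1OC`) gives 26400 nM and compound 3 (`COc1cc2ncnc(Nc3ccc(F)c(Cl)c3)c2cc1NC(=O)N/N=C/c1ccc(F)cc1`) gives 26600 nM. Compound 3 lies within the scatter of both other compounds, so no order can be drawn among the three.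

Compound 4 (`COc1cc2ncnc(Nc3ccc(F)c(Cl)c3)c2cc1NC(=O)N/N=C/c1ccc(OC)c(OC)c1OC`) carries 2,3,4-trimethoxyphenyl in place of 4-fluorophenyl on a carbon with a double bond to nitrogen. The nearest evidence is a 1.3-fold lower number from compound 1 to compound 2 (0.12 log units; within the scatter), with 3,4,5-trimethoxyphenyl in place of 4-fluorophenyl at the same place. Going by the values given here, that group is not the one in compound 4, and no measured compound carries 2,3,4-trimethoxyphenyl. The other measured step, a 1.3-fold lower number from compound 1 to compound 3 (0.12 log units; within the scatter), has methyl in place of oxolan-3-yl on an oxygen on an aromatic ring and shows the same ether as compound 3.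

No change beyond the scatter is therefore expected in this assay. The expected step is a 1.1-fold lower number from compound 3 to compound 4 (0.03 log units; within the scatter). Compound 4 is estimated at 25000 nM, with an expected range of 11000 nM to 55000 nM.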

Compound 4, half-maximal inhibitory concentration: 32800 nM
Beside the measured number, compound 4's estimate is 1.3-fold (0.12 log units) below it, and the stated range covers the measured number.
By their numbers in this assay, from the lowest: compounds 2, 3, 4 and 1 (each within the scatter of the next).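

Going by these compounds alone, compound 4 gives the first reading of 2,3,4-trimethoxyphenyl at this place, and on the methyl ether the change from 4-fluorophenyl gives a 1.2-fold higher number from compound 3 to compound 4 (0.09 log units; within the scatter) in this assay. The earlier trimethoxyphenyl step, a 1.3-fold lower number from compound 1 to compound 2 (0.12 log units; within the scatter), had a different substitution pattern on the oxolan-3-yl ether; with this second step, both trimethoxyphenyl groups, on two different ethers, stay within the scatter of 4-fluorophenyl, although 2,3,4-trimethoxyphenyl has 3 hydrogen-bond acceptors where 4-fluorophenyl has 0. Nothing available bears on why the number holds across this change.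

On these data alone, whether 2,3,4-trimethoxyphenyl behaves the same on the oxolan-3-yl ether stays open. Also open, as far as these compounds go, is whether an aryl group carrying an amine or a carboxylic acid at this place would move the number beyond the scatter.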